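Swapping the Outer Aryl Ring of a Permeable Lead

The compounds below may be only part of what the source reports. "The series", "measured", "known", "first", "only" and "open" are said of these compounds alone.

Compound 1 `CCOc1ccccc1-c1ccc(-c2nc3cnccc3c(N[C@H](CC)C(N)=O)c2C#N)cc1` is the reference point of this small set. Within the data shown here, in an ADME assay on Caco-2 cells (Homo sapiens) for permeability, read by LC-MS, in the apical to basolateral direction, with a stated time of 2 h, tested at 2 uM (a higher number here means that the compound crosses the layer faster, a lower number that the compound crosses the layer more slowly), compound 1 gives 151 nm/s, the highest of the three numbers measured so far. Compound 2 `CCOc1ccccc1-c1ccc(-c2nc3cnccc3c(C[C@H](C)C(=O)O)c2C#N)cc1` gives 43 nm/s, a change of a 3.5-fold lower number from compound 1 to compound 2 (0.55 log units; beyond the scatter). Compound 3 `CCOc1ccccc1-c1ccc(-c2nc3cncc(Cl)c3c(N[C@H](CC)C(N)=O)c2C#N)cc1` gives 17 nm/s, a change of an 8.9-fold lower number from compound 1 to compound 3 (0.95 log units; beyond the scatter). Compound 4 `CC[C@@H](Nc1c(C#N)c(-c2ccc(-c3ccc(Cl)cc3)cc2)nc2cnccc12)C(N)=O` differs from compound 1 elsewhere: 4-chlorophenyl in place of 2-ethoxyphenyl on an aromatic carbon. Among the measured compounds shown here, neither measured step touches this outer ring; the steps from compound 1 to compound 2 and from compound 1 to compound 3 alter groups on the shared core, so they show only that single changes on this scaffold can lower the number noticeably, not what this particular swap does. For the measured compounds named here, with no direct precedent, the expected step is a 1.2-fold lower number from compound 1 to compound 4 (0.07 log units; within the scatter), small enough to sit within the scatter and without a firm direction. Compound 4 is therefore estimated at 130 nm/s, with a range from 60 nm/s to 260 nm/s.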

Compound 4, apparent permeability: 29 nm/s
The estimate for compound 4 lay 4.5-fold (0.65 log units) above the measured number; measured number below the stated range.
By their numbers in this assay, from the lowest: compounds 3, 4 and 2 (each within the scatter of the next, the first and the last beyond it); then compound 1.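

Among these compounds, the outer ring is not a silent position: in this assay the change to 4-chlorophenyl gives a 5.2-fold lower number from compound 1 to compound 4 (0.72 log units; beyond the scatter) and so lowers the number, whereas the earlier steps showed this only for changes on the shared core. The swap alters several things at once, since 2-ethoxyphenyl leaves with its oxygen and hydrogen-bond acceptor and 4-chlorophenyl enters with chlorine, no acceptor, fewer heavy atoms and a different place for its substituent, so this one step cannot be divided among those differences. Nothing available here explains the lower number.

The compounds shown leave open how much of the step belongs to losing the ethoxy group and how much to adding chlorine. An unsubstituted phenyl ring, or an outer ring carrying a methoxy group or an amine, would be needed to separate these contributions.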